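Swapping Trifluoromethyl for Ethyl at a Cytotoxicity Limit

This account rests on a few compounds, and the source may have more. Where it says the series, first, only, none or still open, it means among the compounds named here.

Compound 1 `Fc1ccc(-c2ccc3ncc(-c4noc(C(F)(F)F)n4)cc3c2)cc1` — in a functional assay on RD cells (Homo sapiens) for inhibition, read by luminescence and ATP content, with a stated time of 72 h (a lower number here means that less compound is tolerated, a higher number that more compound is tolerated), compound 1 gives > 7400 nM, a limit of the assay.
Compound 2 `FC(F)(F)c1nc(-c2cnc3ccc(-c4ccc(Cl)cc4)cc3c2)no1` — in this assay compound 2 gives > 200000 nM, also a limit.

Compound 2 thus stands at the limit of > 200000 nM in this assay, at which 1 of the 2 values shown sits, rather than at a measured number. Among the compounds with values here, the one measured step, a step that the two limits leave unreadable from compound 1 to compound 2, runs between two limits and its size cannot be read. Compound 3 `CCc1nc(-c2cnc3ccc(-c4ccc(Cl)cc4)cc3c2)no1` differs from compound 2 in one place: ethyl in place of trifluoromethyl on an aromatic carbon. With no readable step to lean on, no shift beyond the scatter is expected, and compound 2 may simply stay at its limit. Compound 3 is therefore estimated at 150000 nM, between 30000 nM and 300000 nM. That means an expected step of an at least 1.3-fold lower number from compound 2 to compound 3 (0.12 log units; that floor lies within the scatter) within the scatter.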

Compound 3, half-maximal cytotoxic concentration: > 22200 nM
Compound 3 gave a limit, no number; the forecaster's own chance of this, stated with the estimate: 70%; the middle value lies beyond the limit too.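

Compound 2 and compound 3 both give limits, not numbers, and the step between them cannot be read. The compounds shown leave open whether ethyl in place of trifluoromethyl changes the concentration tolerated in this assay at all.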